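Swapping a nitrophenyl for a propyl chain on the shared core

The source may hold more compounds than are shown below. What is called first, only, known or untested is meant among the compounds shown, and "the series" means these compounds.

Measured compounds:
Compound 1 `COc1ccc(C2C(C(=O)OCc3ccccn3)=C(C)NC3=C2C(=O)CCC3)cc1`: 1.9
Compound 2 `CC1=C(C(=O)OCc2ccccn2)C(c2ccccc2[N+](=O)[O-])C2=C(CCCC2=O)N1`: 1.88

Both compounds were measured in a physicochemical assay for lipophilicity, measured as octanol-water partition; on this read-out lower numbers stand for lower lipophilicity and higher numbers for higher lipophilicity. Compound 1 gives 1.9 there, and compound 2 gives 1.88, so the two sit at practically the same value; the step of a number 0.02 log units lower from compound 1 to compound 2 (within the scatter) is within the scatter. Compound 2 therefore stands side by side with compound 1, with nothing to separate them beyond measurement noise.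

Compound 3 `CCCC1C(C(=O)OCc2ccccn2)=C(C)NC2=C1C(=O)CCC2` has not yet been measured in this assay. It differs from compound 2 in one place: propyl in place of 2-nitrophenyl on a saturated ring carbon. Among the measured compounds shown here, the only measured step, a number 0.02 log units lower from compound 1 to compound 2 (within the scatter), exchanged one substituted aromatic ring for another and left the number unchanged. The step to compound 3 is of a different kind, replacing an aromatic ring with a short chain, so that step bears only loosely on it. A modest shift, if any, is expected: a number 0.08 log units lower from compound 2 to compound 3 (within the scatter) is the estimated change from compound 2 to compound 3. For compound 3 the expected value in this assay is 1.8, within a range from 1.4 to 2.3.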

Compound 3, partition coefficient: 2.6
Beside the measured number, compound 3's estimate is 0.80 log units below it; measured number outside the range, above it.
By their numbers in this assay, from the lowest: compounds 2 and 1 (each within the scatter of the next); then compound 3.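

At this position, on a saturated ring carbon, the group carried there can move the number in this assay: propyl in place of 2-nitrophenyl gives a number 0.72 log units higher from compound 2 to compound 3 (beyond the scatter), and propyl in place of 4-methoxyphenyl gives a number 0.70 log units higher from compound 1 to compound 3 (beyond the scatter). The two aromatic groups alone had suggested that the position made little difference, but a change from a substituted aromatic ring to a short chain with no ring shifts the value beyond the scatter, whichever of the two aromatic groups it replaces. Nothing available here explains why the number moves with this change.

The three compounds change several things at once, since propyl differs from both aromatic groups in ring, size and atoms, so they cannot show which of these differences matters. A cyclohexyl group would keep a ring while removing the aromatic character, and a methyl group or a longer chain such as pentyl on the same carbon would show whether the number follows the length of the chain.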